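This account rests on a few compounds, and the source may have more. Where it says the series, first, only, none or still open, it means among the compounds named here.

In a functional assay on MIA PaCa-2 cells (Homo sapiens) for cytotoxicity, read by MTT assay, with a stated time of 72 h (a lower number here means a stronger inhibitor, a higher number a weaker inhibitor), compound 1 `COC1=CC(=O)c2c(COc3ccc(N)cc3)c(C)n(C)c2C1=O` gives 160 nM and compound 2 `COC1=CC(=O)c2c(COc3ccc(C(F)(F)F)cc3)c(C)n(C)c2C1=O` gives 311 nM, so the two stand level within the scatter. Compound 3 `COC1=CC(=O)c2c(COc3ccc(F)cc3F)c(C)n(C)c2C1=O` differs from compound 1 as follows: 2,4-difluorophenyl in place of 4-aminophenyl on an oxygen on a saturated carbon. In words, 2,4-difluorophenyl stands in place of 4-aminophenyl on an oxygen on a saturated carbon. Within the data shown here, one measured step bears on this, as it also removes the amino group: a 1.9-fold higher number from compound 1 to compound 2 (0.29 log units; within the scatter). That step offers no reason to expect a large shift. The expected step is a 1.4-fold higher number from compound 1 to compound 3 (0.16 log units; within the scatter), slightly upward and within the scatter. For compound 3 the estimated value is 230 nM, with an expected range of 90 nM to 600 nM.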

Compound 3, half-maximal inhibitory concentration: 75 nM
The estimate for compound 3 lay 3.1-fold (0.49 log units) above the measured number, outside the stated range (below it).
By their numbers in this assay, from the lowest: compound 3; then compounds 1 and 2 (each within the scatter of the next).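

In this assay, the group on this oxygen on a saturated carbon can be changed with a step beyond the scatter (a 2.1-fold lower number from compound 1 to compound 3 (0.33 log units; beyond the scatter)), which the earlier pair, level within the scatter, did not show. The change removes the amino group and its hydrogen-bond donor, so at this place in the series, a low number does not depend on that amino group. Nothing measured here gives a reason for the drop.

Still open, on these data alone, is how 4-fluorophenyl, carrying a single fluorine, would compare at this place. The same holds for a non-aromatic group such as cyclohexyl.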